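Methoxy added to a para-aminochalcone: a shift in its core

The source may hold more compounds than are shown below. What is called first, only, known or untested is meant among the compounds shown, and "the series" means these compounds.

Compound 1 `Nc1ccc(/C=C/C(=O)c2ccccc2)cc1` and compound 3 `Nc1ccc(C(=O)/C=C/c2ccccc2)cc1` are built from the same atoms joined differently; how their two cores differ is not broken down here. Among the compounds with values here, in a functional assay on HeLa cells (Homo sapiens) for antiproliferative activity, with a stated time of 48 h (a higher number here means a weaker inhibitor, a lower number a stronger inhibitor), compound 1 gives 36000 nM, while compound 3 gives 7700 nM, the lowest number of the three measured so far. Compound 2 `COc1cccc(C(=O)/C=C/c2ccc(N)cc2)c1` carries one change on the core of compound 1, (methoxy in place of hydrogen on an aromatic carbon); in this assay compound 2 gives 33000 nM, a step of a 1.1-fold lower number from compound 1 to compound 2 (0.04 log units; within the scatter). Compound 4 `COc1cccc(/C=C/C(=O)c2ccc(N)cc2)c1` carries the same change on the core of compound 3, (methoxy in place of hydrogen on an aromatic carbon). Since that step on compound 1 stayed within the scatter, the step to compound 4 is expected to be small as well, about a 1.1-fold lower number from compound 3 to compound 4 (0.04 log units; within the scatter). Compound 4 is therefore estimated at 7000 nM, with a range from 3500 nM to 14000 nM.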

Compound 4, half-maximal inhibitory concentration: 19000 nM
The estimate for compound 4 lay 2.7-fold (0.43 log units) below the measured number; measured number outside the range, above it.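

In this assay, methoxy in place of hydrogen on an aromatic carbon gave a 2.5-fold higher number from compound 3 to compound 4 (0.39 log units; beyond the scatter), and this step does not match the one on the other core: the same change on two cores in this assay, a 1.1-fold lower number (0.04 log units; within the scatter) from compound 1 to compound 2 and a 2.5-fold higher number (0.39 log units; beyond the scatter) from compound 3 to compound 4, 2.7-fold (0.43 log units) apart, beyond the scatter of two such steps In this pair of cores, then, the size of the step on one core did not predict its size on the other. This does not explain why the two cores differ, and two pairs of compounds establish no rule for the whole series.

The compounds shown leave open whether a hydroxyl, a fluorine or a longer alkoxy chain in the same place would also separate the two cores. On these data alone, whether methoxy elsewhere on the ring would do so also remains open.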